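Cyclopentyl for Phenyl on the Benzimidazole Carbon

The source may hold more compounds than are shown below. What is called first, only, known or untested is meant among the compounds shown, and "the series" means these compounds.

Measured so far:
- compound 1, `CCCc1ccc(S(=O)(=O)NC(=O)OCCC(F)(F)C(F)(F)F)c(-c2ccc(Cn3c(C(C)(C)C)nc4ccccc43)cc2)c1`: 6 nM
- compound 2, `CCCCOC(=O)NS(=O)(=O)c1ccc(CCC)cc1-c1ccc(Cn2c(-c3ccccc3)nc3ccccc32)cc1`: 590 nM

Both compounds were tested in an assay on membranes from HEK293 cells for displacement of a labelled ligand from Type-2 angiotensin II receptor (Homo sapiens), read by radioligand binding; on this read-out lower numbers stand for stronger inhibition and higher numbers for weaker inhibition. Compound 2 stands at the highest of the two numbers; its nearest neighbour, compound 1, gives a lower number, a gap beyond the scatter, though the two compounds differ in more than one place, so only the two values themselves can be compared.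

Compound 3, `CCCCOC(=O)NS(=O)(=O)c1ccc(CCC)cc1-c1ccc(Cn2c(C3CCCC3)nc3ccccc32)cc1`, has not yet been measured. It differs from compound 2 in one place: cyclopentyl in place of phenyl on an aromatic carbon. Among the measured compounds shown here, no measured pair shows this exact change. Compound 1, which carries a non-aromatic group at the same place and gives 6 nM, suggests that a non-aromatic group there is compatible with a low number. Compound 3 is therefore expected to give 80 nM, with a range of 20 nM to 320 nM. The expected step of a 7.4-fold lower number from compound 2 to compound 3 (0.87 log units; beyond the scatter) is a moderate fall beyond the scatter, not a return to the level of compound 1.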

Compound 3, inhibition constant: 35 nM
Compound 3: the middle estimate sits 2.3-fold (0.36 log units) above what was measured, and the stated range covers the measured number.
By their numbers in this assay, from the lowest: compound 1; then compound 3; then compound 2.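

In this assay, putting cyclopentyl in place of phenyl gives a 17-fold lower number from compound 2 to compound 3 (1.23 log units; beyond the scatter), which shows directly that the number is sensitive to the group on this aromatic carbon between two ring nitrogen atoms. An aromatic ring is therefore not needed here for binding, and in this pair the non-aromatic ring gives the lower number, although neither group carries hydrogen-bond donors, hydrogen-bond acceptors or a net charge. No measurement here explains the step, and this single swap changes ring size and aromatic character together.

The compounds shown do not separate those two changes, and a cyclohexyl ring would be the natural group to compare with both phenyl and cyclopentyl. As far as these compounds go, it also remains open whether a smaller cyclopropyl ring fits this trend, and whether the same swap gives a similar step on the core of compound 1.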